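Replacing the hydroxy-methoxy ring in a thioether enone series

A few compounds are considered here, and "the series" means these few. Any claim that something is new, unique, unknown or untested is made for them only; others in the source may bear on it.

Measured so far in a functional assay on DU-145 cells (Homo sapiens) for inhibition, read by trypan blue exclusion, with a stated time of 96 h; on this read-out higher numbers stand for weaker inhibition of growth and lower numbers for stronger inhibition of growth:
compound 1, `COc1cc(/C=C(/Sc2ccc(Br)cc2)C(=O)c2ccc(Br)cc2)ccc1O`: 1000 nM
compound 2, `COc1ccccc1/C=C(/Sc1ccc(C)cc1)C(=O)c1ccc(Br)cc1`: 9000 nM
compound 3, `O=C(/C(=C\c1ccc(O)c([N+](=O)[O-])c1)Sc1ccccc1Br)c1ccc(Br)cc1`: 10000 nM

Compound 1 holds the lowest number of the three, and its gaps to compound 2 and to compound 3 both lie beyond the usual scatter, so it stands as the strongest inhibitor of growth here. Compound 4, `O=C(/C(=C\c1ccc(Cl)cc1Cl)Sc1ccc(Br)cc1)c1ccc(Br)cc1`, has not yet been measured in this assay. It differs from compound 1 by 2,4-dichlorophenyl in place of 4-hydroxy-3-methoxyphenyl on a double-bonded chain carbon bound to a double-bonded chain carbon. Two measured compounds lacking that hydroxyl-bearing ring arrangement show higher numbers, so the step of a 3.0-fold higher number from compound 1 to compound 4 (0.48 log units; beyond the scatter) is expected to be a modest weakening beyond the scatter. Compound 4 is therefore estimated at about 3000 nM, within a range from 700 nM to 15000 nM.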

Compound 4, concentration for 50% growth inhibition: 1000 nM
Compound 4: middle estimate off by 3.0-fold (0.48 log units), on the high side; the measured number falls inside the stated range.
By their numbers in this assay, from the lowest: compounds 1 and 4 (each within the scatter of the next); then compounds 2 and 3 (each within the scatter of the next).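

In this assay, putting 2,4-dichlorophenyl in place of 4-hydroxy-3-methoxyphenyl gives no change at the digits printed from compound 1 to compound 4 (within the scatter). This position therefore tolerates a ring with 0 hydrogen-bond donors and 0 hydrogen-bond acceptors, so in this pair the hydroxy and methoxy groups are not required for this level of growth inhibition. No measured evidence explains this result. From the compounds shown here alone, whether a phenyl ring carrying an amine or a carboxylic acid would fit this position equally well remains open. Also open, going by these compounds, is whether 2,4-dichlorophenyl would behave the same way with other groups on the sulfur.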